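From Ethoxy to Bromo on a Shared Core

A few compounds are considered here, and "the series" means these few. Any claim that something is new, unique, unknown or untested is made for them only; others in the source may bear on it.

In a functional assay on HaCaT cells (Homo sapiens) for antiproliferative activity, read by sulforhodamine B assay, with a stated time of 3 days (a higher number here means a weaker inhibitor, a lower number a stronger inhibitor), compound 1 (`COC(=O)c1cc(CCc2cc(OC)ccc2O)ccc1O`) gives 1100 nM and compound 2 (`CCOc1ccc(OC)cc1CCc1ccc(O)c(C(=O)OC)c1`) gives 120 nM, the lower of the two numbers. Compound 3 (`COC(=O)c1cc(CCc2cc(OC)ccc2Br)ccc1O`) carries bromo in place of ethoxy on an aromatic carbon. Going by the values given here, the one measured step that bears on this change is a 9.2-fold lower number from compound 1 to compound 2 (0.96 log units; beyond the scatter), with ethyl in place of hydrogen on an oxygen on an aromatic ring. Among the compounds with values here, no bromo compound has been measured, so only a partial loss of that step is expected, toward a higher number, giving an expected 2.1-fold higher number from compound 2 to compound 3 (0.32 log units; beyond the scatter). For compound 3 the estimated value is 250 nM, with an expected range of 70 nM to 900 nM.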

Compound 3, half-maximal inhibitory concentration: 210 nM
For compound 3 the middle estimate is 1.2-fold (0.08 log units) above the measured one, within the range that was stated.
By their numbers in this assay, from the lowest: compounds 2 and 3 (each within the scatter of the next); then compound 1.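

In this assay at this position, para to a methoxy group, bromo in place of ethoxy gives a 1.8-fold higher number from compound 2 to compound 3 (0.24 log units; within the scatter) and bromo in place of hydroxy gives a 5.2-fold lower number from compound 1 to compound 3 (0.72 log units; beyond the scatter). The lower numbers seen here thus do not depend on an oxygen or a chain: a single bromine atom, with no hydrogen-bond acceptor, matches ethoxy within the scatter. Nothing given here explains this result. Open, going by these compounds, is whether chloro or propoxy at this position would keep the number in the same range, and whether an amine would stand nearer to compound 1.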